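This account rests on a few compounds, and the source may have more. Where it says the series, first, only, none or still open, it means among the compounds named here.

Working notes on the series. The shared core is that of compound 1, `CN(C)C(=S)N/N=C1/C(=O)Nc2ccccc21`. In an ADME assay on RD cells (Homo sapiens) for cytotoxicity (on this read-out lower numbers stand for higher toxicity in this test and higher numbers for lower toxicity in this test), compound 1 gives > 25000 nM, which is a limit of the assay and not a number. Compound 2 is `Cc1cccc(NC(=O)N/N=C2\C(=O)Nc3ccccc32)c1`. In this assay compound 2 gives > 25000 nM, again only a limit. Compound 3, `O=C1Nc2ccccc2/C1=N/NC(=S)N1CCCCC1`, carries piperidin-1-yl on the thiocarbonyl carbon. In this assay compound 3 gives > 25000 nM, also a limit. Where compound 3 stands is therefore set only by the limit of > 25000 nM in this assay, at which 3 of the 3 values shown sit: no number separates compound 3 from compound 1 or compound 2, and none of the three can be called the least or the most toxic. For the measured compounds named here, no step between two measured compounds is available, so the size of any change has not been seen.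

Compound 4, `CNC(=S)N/N=C1\C(=O)Nc2ccccc21`, differs from compound 3 by methylamino in place of piperidin-1-yl on a thiocarbonyl carbon. Going by the values given here, with every value so far resting at the limit, the expectation is a step that the limit leaves unreadable from compound 3 to compound 4, that is, none beyond the scatter. For compound 4 the estimate in this assay is 30000 nM, within 12000 nM to 80000 nM, and the reading is expected most likely to come back once more as a limit rather than a number.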

Compound 4, half-maximal cytotoxic concentration: > 25000 nM
Compound 4 ended at the assay's limit (the forecaster's own chance of this, stated with the estimate: 85%); the middle value lies beyond the limit too.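

Compound 3 and compound 4 both rest at a limit of the assay and not at a number, so no step can be read between them: the limit of > 25000 nM in this assay, at which 4 of the 4 values shown sit.

Still open, as far as these compounds go, is how far methylamino and piperidin-1-yl on a thiocarbonyl carbon differ in this assay, and whether any compound on the shared core gives a number there.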